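Changing the Amide Ring from Pyridine to Phenyl

A few compounds are considered here, and "the series" means these few. Any claim that something is new, unique, unknown or untested is made for them only; others in the source may bear on it.

Compound 2 `COc1ccc(Cn2c(CCc3ccccc3)nnc2[C@H](NC(=O)c2ccccn2)c2c[nH]c3ccccc23)c(OC)c1` gives 1.1 nM in an in vitro assay on LLC-PK1 cells for displacement of a labelled ligand from growth hormone secretagogue receptor type 1 (Homo sapiens) (a lower number here means a stronger inhibitor, a higher number a weaker inhibitor), the lowest of the three numbers measured. Compound 1 `COc1ccc(Cn2c(CCc3c[nH]c4ccccc34)nnc2[C@H](NC(=O)c2ccccn2)c2c[nH]c3ccccc23)c(OC)c1` gives 1.8 nM, and the step of a 1.6-fold lower number from compound 1 to compound 2 (0.21 log units; within the scatter) stays within the scatter. Compound 3 `CCc1ccc(Cn2c(CCc3ccccc3)nnc2[C@H](NC(=O)c2ccccn2)c2c[nH]c3ccccc23)cc1` gives 67 nM, and the step of a 61-fold higher number from compound 2 to compound 3 (1.78 log units; beyond the scatter) is large. Compound 4 `COc1ccc(Cn2c(CCc3ccccc3)nnc2[C@H](NC(=O)c2ccccc2)c2c[nH]c3ccccc23)c(OC)c1` differs from compound 2 by phenyl in place of pyridin-2-yl on a carbonyl carbon. Among the compounds with values here, neither measured step touches the carbonyl carbon, so no measured step bears directly on this change; the two steps only show that one part of the shared core tolerates change while another does not, and the amide end remains untested. A step of a 2.7-fold higher number from compound 2 to compound 4 (0.44 log units; beyond the scatter) is therefore expected, small or at most a modest weakening. Compound 4 is estimated at 3 nM. Its expected range runs from 0.8 nM to 12 nM.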

Compound 4, half-maximal inhibitory concentration: 11.8 nM
Compound 4: the middle estimate sits 3.9-fold (0.59 log units) below what was measured; the range from low to high includes it.
By their numbers in this assay, from the lowest: compounds 2 and 1 (each within the scatter of the next); then compound 4; then compound 3.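

The amide end, untested until now, proves sensitive to change: in this assay, phenyl in place of pyridin-2-yl on a carbonyl carbon gives an 11-fold higher number from compound 2 to compound 4 (1.03 log units; beyond the scatter), a large step. The two rings are the same size, and the entering phenyl has only carbon where pyridin-2-yl carries a nitrogen, its hydrogen-bond acceptor. No available measurement explains why this change matters. Still open, going by these compounds, is how a pyridin-3-yl or pyrimidin-2-yl group on the same carbonyl carbon would compare with pyridin-2-yl, and whether the step would be as large with the 1H-indol-3-yl of compound 1.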